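Difluoro swap on the limit-bound compound 3

A few compounds are considered here, and "the series" means these few. Any claim that something is new, unique, unknown or untested is made for them only; others in the source may bear on it.

- compound 1 `CSCC[C@H](NC(=O)c1ccc(CN(Cc2cc(F)cc(F)c2)c2ccccc2)cc1-c1ccccc1C)C(=O)O`: 1.9 h
- compound 2 `CSCC[C@H](NC(=O)c1ccc(CN(Cc2cc(F)cc(F)c2)c2cccnc2)cc1-c1ccccc1C)C(=O)O`: 1 h
- compound 3 `CSCC[C@H](NC(=O)c1ccc(CN(Cc2ccccc2)Cc2cncs2)cc1-c1ccccc1C)C(=O)O`: < 0.4 h

In an ADME assay on the whole organism for metabolic stability, with Rattus norvegicus as the target (on this read-out higher numbers stand for a longer-lived compound and lower numbers for a shorter-lived compound), compound 3 gives < 0.4 h, which is a limit and not a number. The only anchor for this starting point is the limit of < 0.4 h in this assay, at which 1 of the 3 values shown sits.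

Compound 4 `CSCC[C@H](NC(=O)c1ccc(CN(Cc2cc(F)cc(F)c2)Cc2cncs2)cc1-c1ccccc1C)C(=O)O` differs from it by 3,5-difluorophenyl in place of phenyl on a saturated chain carbon bound to an amine nitrogen. Among the measured compounds shown here, the only measured step, a 1.9-fold lower number from compound 1 to compound 2 (0.28 log units; within the scatter), lies within the scatter and is a swap of pyridin-3-yl for phenyl on an amine nitrogen, so it says little directly about this change.

Some indirect guidance remains. Compound 1 at 1.9 h and compound 2 at 1 h both carry the 3,5-difluorobenzyl group, but neither shares the other amine substituent of compound 3. On that basis a modest rise in this assay is expected, and the estimated at least 1.7-fold higher number from compound 3 to compound 4 (0.24 log units; that floor lies within the scatter) remains uncertain because the start is the limit of < 0.4 h in this assay, at which 1 of the 3 values shown sits. The expected half-life for compound 4 is 0.7 h, with an estimated range of 0.3 h to 1.5 h.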

Compound 4, half-life: 1.13 h
Compound 4: middle estimate off by 1.6-fold (0.21 log units), on the low side, within the range that was stated.
By their numbers in this assay, from the lowest: compounds 2, 4 and 1 (each within the scatter of the next). At a limit, below all of these: compound 3.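

In this assay, among the compounds shown here, 3,5-difluorophenyl in place of phenyl on a saturated chain carbon bound to an amine nitrogen gives an at least 2.8-fold higher number from compound 3 to compound 4 (0.45 log units; beyond the scatter), the first step that lies beyond the scatter. That size is only a floor, because compound 3 stands at a limit and not at a number: the limit of < 0.4 h in this assay, at which 1 of the 4 values shown sits.

With the 3,5-difluorobenzyl group held constant, the other substituent on the amine nitrogen brings no separation in this assay, with a 1.1-fold higher number from compound 2 to compound 4 (0.05 log units; within the scatter) and a 1.7-fold lower number from compound 1 to compound 4 (0.23 log units; within the scatter).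

Open, on these data alone, is whether a single fluorine or a chlorine on the benzyl group would give a step of similar size. Also open, as far as these compounds go, is whether the benzyl to 3,5-difluorobenzyl step carries over when the amine nitrogen bears phenyl or pyridin-3-yl, as in compound 1 and compound 2.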